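Imidazole Nitrogen Aryl Swap: Expectation for Compound 3

The compounds below may be only part of what the source reports. "The series", "measured", "known", "first", "only" and "open" are said of these compounds alone.

Measured compounds:
- Compound 1, `Cc1ccc(-n2c(-c3coc4cc(C)c(Cl)cc4c3=O)nc(-c3ccccc3)c2-c2ccccc2)cc1`: 6250 nM
- Compound 2, `Cc1cc2occ(-c3nc(-c4ccccc4)c(-c4ccccc4)n3-c3cccc([N+](=O)[O-])c3)c(=O)c2cc1Cl`: 25000 nM

In a functional assay on HepG2 cells (Homo sapiens) for inhibition, read by MTT assay, with a stated time of 72 h (on this read-out higher numbers stand for weaker inhibition and lower numbers for stronger inhibition), compound 2 gives 25000 nM, the highest of the two numbers; its nearest neighbour is compound 1 at 6250 nM. Compound 3, `Cc1cc2occ(-c3nc(-c4ccccc4)c(-c4ccccc4)n3-c3ccc(Cl)cc3)c(=O)c2cc1Cl`, has not yet been measured. It differs from compound 2 in one place: 4-chlorophenyl in place of 3-nitrophenyl on an aromatic nitrogen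

Among the measured compounds shown here, the only measured step that bears on this change is a 4.0-fold higher number from compound 1 to compound 2 (0.60 log units; beyond the scatter). That step put a 3-nitrophenyl on the aromatic nitrogen and raised the number; compound 3 takes that group off again and puts a 4-chlorophenyl there, a group with no hydrogen-bond acceptors, as compound 1 carries none there. The step is therefore expected to run the other way, and compound 3 is expected to give 8000 nM in this assay, within 3000 nM to 25000 nM, which would mean a 3.1-fold lower number from compound 2 to compound 3 (0.49 log units; beyond the scatter).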

Compound 3, half-maximal inhibitory concentration: 1560 nM
Beside the measured number, compound 3's estimate is 5.1-fold (0.71 log units) above it; the whole stated range lies above it.
By their numbers in this assay, from the lowest: compound 3; then compound 1; then compound 2.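

In this assay, 4-chlorophenyl in place of 3-nitrophenyl on the aromatic nitrogen gives a 16-fold lower number from compound 2 to compound 3 (1.20 log units; beyond the scatter) and is a large step, so the number at this position can fall well past that of compound 1, which the earlier pair did not show. Chloro in place of methyl on an aromatic carbon of that phenyl ring gives a 4.0-fold lower number from compound 1 to compound 3 (0.60 log units; beyond the scatter) and separates two groups with no hydrogen-bond acceptors, so the lack of such acceptors does not by itself fix the number. Nothing given here explains either step.

The compounds shown leave open how much of the step belongs to the identity of the group on the phenyl ring and how much to its place there, a question that 3-chlorophenyl or 4-nitrophenyl would address. They also leave open how an amine or a carboxylic acid on that ring would read in this assay.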